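Esterifying the acid of compound 2

The source may report more compounds than this note shows. Statements on the series, on what has been measured and on what is new or still open speak of the compounds shown alone.

Compound 1 `c1ccc(Sc2ccc(NC3=NCCN3)cc2)cc1` and compound 2 `O=C(O)c1ccc(Sc2ccc(NC3=NCCN3)cc2)cc1` share the same core and differ only by the carboxy group on an aromatic carbon. In an assay (Rattus norvegicus) for binding affinity to prostacyclin receptor (Homo sapiens), read by radioligand binding (a lower number here means a stronger inhibitor, a higher number a weaker inhibitor), compound 1 gives 794 nM. For compound 2 the assay reports only a limit, < 10000 nM, not a number. The step from compound 1 to compound 2, a step that the limit leaves unreadable from compound 1 to compound 2, is therefore of unreadable size, and the standing of compound 2 on the numbers shown is no more than that it sits at the limit (the limit of < 10000 nM in this assay, at which 1 of the 2 values shown sits).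

Compound 3 `CCOC(=O)c1ccc(Sc2ccc(NC3=NCCN3)cc2)cc1` is the ethyl ester of compound 2; the change is ethyl in place of hydrogen on an oxygen next to a carbonyl group. Within the data shown here, no measured step bears directly on this change: the only step is the one from compound 1 to compound 2, which the limit leaves unreadable. What remains as a guide is compound 1, which carries neither carboxy nor ethoxycarbonyl and gives 794 nM. Compound 3 is expected to land between the number of compound 1 and the limit of compound 2, an estimated 3000 nM with a range of 600 nM to 12000 nM, meaning an expected step that the limit leaves unreadable from compound 2 to compound 3 in this assay, toward stronger binding but with wide uncertainty.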

Compound 3, inhibition constant: 50.1 nM
The estimate for compound 3 lay 60-fold (1.78 log units) above the measured number, outside the stated range (below it).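

In this assay the aromatic carbon that carries the new group now gives a readable result: ethoxycarbonyl in place of hydrogen produces a 16-fold lower number from compound 1 to compound 3 (1.20 log units; beyond the scatter) on the shared core. Among these compounds, this is the first substituent with a measured number at this place, and it shows that the place can hold the ethyl ester with stronger binding than compound 1, which has only hydrogen there. Compound 2 has only a limit, < 10000 nM in this assay, and the steps that join it to the other compounds, including hydroxy to ethoxy, cannot be read because that limit gives them no size: the limit of < 10000 nM in this assay, at which 1 of the 3 values shown sits.

As far as these compounds go, whether the stronger binding depends on the ethyl group, on the ester carbonyl or on any substituent at this carbon remains open, and a methyl ester, a longer chain such as a butyl ester, a primary amide or a simple ketone at the same place would help to separate these readings. The effect of the carboxylic acid itself also stays undefined until compound 2 has a number rather than a limit, and the compounds shown give no cause for the step to the ethyl ester.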